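Compound 2 to compound 3: a tolerance estimate

The source may report more compounds than this note shows. Statements on the series, on what has been measured and on what is new or still open speak of the compounds shown alone.

Measured so far in a toxicity assay on Huh-7.5 cells (Homo sapiens) for inhibition, read by MTT assay, with a stated time of 96 h; a lower number here means that less compound is tolerated, a higher number that more compound is tolerated:
- compound 1 `CCC(=O)Nc1cc(C(=O)Nc2ccc(OC)cc2)ccc1OCCCCl` gives 158000 nM
- compound 2 `CCC(=O)Nc1cc(C(=O)Nc2ccc(OC)cc2)ccc1OC` gives 109000 nM

For the measured compounds named here, compound 2 stands level with the only other measured compound, since the numbers show a 1.4-fold lower number from compound 1 to compound 2 (0.16 log units; within the scatter). That step places hydrogen in place of 2-chloroethyl on a saturated chain carbon bound to an oxygen on an aromatic ring. The next compound, compound 3 `CCC(=O)Nc1cc(C(=O)Nn2c(C)nnc2S)ccc1OC`, differs from compound 2 elsewhere. It has 3-methyl-5-sulfanyl-4H-1,2,4-triazol-4-yl in place of 4-methoxyphenyl on an amide-type nitrogen. Going by the values given here, no measured step touches that nitrogen, so the one available step bears on this change only indirectly, and it offers no direction. A step beyond the scatter in this assay is therefore not expected, and the reading stays anchored on compound 2 at 109000 nM, with a wide margin for the untested exchange. The expected change is a 1.2-fold higher number from compound 2 to compound 3 (0.08 log units; within the scatter). For compound 3 the estimated value is 130000 nM, within an expected range of 50000 nM to 300000 nM.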

Compound 3, half-maximal cytotoxic concentration: > 200000 nM
Compound 3: a limit, no number; the forecaster's own chance of this, stated with the estimate: 25%; middle value at least 1.5-fold (0.18 log units) from the limit.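

In this assay compound 3 gives > 200000 nM, which is a limit of the assay and not a number. For the compounds shown here, this is the first reading of a change on the amide-type nitrogen, where 3-methyl-5-sulfanyl-4H-1,2,4-triazol-4-yl in place of 4-methoxyphenyl gives an at least 1.8-fold higher number from compound 2 to compound 3 (0.26 log units; that floor lies within the scatter), so the exchange shows no sign of a lower tolerance, though its floor alone does not set it apart from compound 2. How far the step reaches cannot be told, because the reading is a limit: the limit of > 200000 nM in this assay, at which 1 of the 3 values shown sits.

As far as these compounds go, it remains open which part of the entering group goes with this reading: the sulfanyl, the methyl or the five-membered aromatic ring itself. Also open, from the compounds shown here alone, is how an amine or a carboxylic acid on that nitrogen would read in this assay.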